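A few compounds are considered here, and "the series" means these few. Any claim that something is new, unique, unknown or untested is made for them only; others in the source may bear on it.

Compound 1 `Cc1cc(C)c2ccc(=O)n(CCN(C)C)c2n1` gives 3.93 ug/mL in an assay on isolated protein (strain Charles River) for antagonist activity at histamine H2 receptor (Rattus norvegicus) (a lower number here means that less compound is needed, a higher number that more compound is needed for the effect), the lowest of the two numbers measured. Compound 2 `Cc1cc(Cl)nc2c1ccc(=O)n2CCN(C)C` gives 9.23 ug/mL, and the step of a 2.3-fold higher number from compound 1 to compound 2 (0.37 log units; beyond the scatter) puts chloro in place of methyl on an aromatic carbon. Compound 3 `Cc1cc(C)c2ccc(=O)n(CCN3CCCCC3)c2n1` differs from compound 1 by piperidin-1-yl in place of dimethylamino on a saturated chain carbon, two bonds along the chain from an aromatic nitrogen. Among the measured compounds shown here, the single measured step alters an aromatic carbon, not the amine on the chain, so no step bears directly on this change, and the expectation is a step of a 1.0-fold higher number from compound 1 to compound 3 (0.01 log units; within the scatter) within the scatter. For compound 3 the estimate in this assay is 4 ug/mL, ranging from 1.5 ug/mL to 11 ug/mL.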

Compound 3, half-maximal effective concentration: 3.05 ug/mL
The estimate for compound 3 lay 1.3-fold (0.12 log units) above the measured number; low and high end bracket the measured number.
By their numbers in this assay, from the lowest: compounds 3 and 1 (each within the scatter of the next); then compound 2.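

Putting piperidin-1-yl in place of dimethylamino on this saturated chain carbon gives a 1.3-fold lower number from compound 1 to compound 3 (0.11 log units; within the scatter) in this assay, so the two amines cannot be told apart here. The earlier step changed an aromatic carbon, whereas this one shows that a six-membered ring with more heavy atoms can sit on the chain without moving the number beyond the scatter. Nothing available explains this result. As far as these compounds go, whether pyrrolidin-1-yl, morpholin-4-yl or a longer chain would also leave the number within the scatter remains open. So does whether chloro in place of methyl would give a similar step with piperidin-1-yl on the chain.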